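One Aryl Swap on the Amide-Type Nitrogen, Tolerance Expected

The compounds below may be only part of what the source reports. "The series", "measured", "known", "first", "only" and "open" are said of these compounds alone.

Compound 1 `COc1cccc(NC(=O)/C=C/c2coc3cc(OC)ccc3c2=O)c1` and compound 2 `Cc1ccccc1NC(=O)/C=C/c1coc2cc(O)ccc2c1=O` share a core and differ in the aryl group on the amide-type nitrogen as well as in one substituent on the core. Within the data shown here, in an ADME assay on HepG2 2.2.15 cells (Homo sapiens) for cytotoxicity, read by MTT assay, with stated times of 48 h and 9 days (a lower number here means that less compound is tolerated, a higher number that more compound is tolerated), compound 1 gives 1130000 nM, the highest of the two numbers known so far. Compound 2 gives 374000 nM in this assay, a lower number whose gap to compound 1 lies beyond the scatter of repeated measurements. Among the measured compounds shown here, no step between compounds differing in a single place has been measured, so these two values show only that compound 1 is tolerated at a higher concentration than compound 2.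

Compound 3 `CCOc1ccc(NC(=O)/C=C/c2coc3cc(OC)ccc3c2=O)cc1` has not yet been measured. It differs from compound 1 by one change: 4-ethoxyphenyl in place of 3-methoxyphenyl on an amide-type nitrogen. The measured pair says nothing about this particular exchange. The expected step is a 1.3-fold lower number from compound 1 to compound 3 (0.10 log units; within the scatter), which is none beyond the scatter. Compound 3 is therefore estimated at 900000 nM in this assay, with a range from 400000 nM to 1600000 nM.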

Compound 3, half-maximal cytotoxic concentration: 460000 nM
The estimate for compound 3 lay 2.0-fold (0.29 log units) above the measured number; the range from low to high includes it.
By their numbers in this assay, from the lowest: compounds 2 and 3 (each within the scatter of the next); then compound 1.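

Among these compounds, on the amide-type nitrogen of the shared core, the exchange of 3-methoxyphenyl for 4-ethoxyphenyl provides the first single change that can be read in this assay, and it gives a 2.5-fold lower number from compound 1 to compound 3 (0.39 log units; beyond the scatter) as a modest step. The aryl group at this position therefore matters to the number, even though the counts of hydrogen-bond donors and acceptors do not differ between the leaving and entering groups and the entering group is only slightly larger in heavy atoms. Nothing measured here gives a reason for this step.

The exchange alters both where the alkoxy group sits on the phenyl ring and the length of its chain, so this one step cannot separate the two, and 4-methoxyphenyl or 3-ethoxyphenyl on the same nitrogen would be needed to tell them apart. The compounds shown also leave open how the number would respond to an aryl group bearing an amine or a carboxylic acid, or to a longer alkoxy chain such as butoxy.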